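The source may report more compounds than this note shows. Statements on the series, on what has been measured and on what is new or still open speak of the compounds shown alone.

For the measured compounds named here, compound 1 `N=c1c(C(N)=O)cc(Cl)cn1Cc1ccccc1` gives 30 nM in an assay on CHO-K1 cells for displacement of a labelled ligand from Alpha-1D adrenergic receptor (Homo sapiens), read by scintillation counting, with a stated time of 60 min (a higher number here means a weaker inhibitor, a lower number a stronger inhibitor), the lowest of the two numbers known. Going by the values given here, the nearest is compound 2 `N=c1c(C(N)=O)cc(Br)cn1Cc1ccccc1`, which in this assay gives 160 nM; the single measured step, a 5.3-fold higher number from compound 1 to compound 2 (0.73 log units; beyond the scatter), is bromo in place of chloro on an aromatic carbon. Compound 3 `N=c1c(C(N)=O)cc(Cl)cn1Cc1cccnc1` differs from compound 1 by pyridin-3-yl in place of phenyl on a saturated chain carbon bound to an aromatic nitrogen. Among the compounds with values here, no measured step bears on this change, so the halogen step offers no guide. Compound 3 is therefore expected to show a 1.3-fold higher number from compound 1 to compound 3 (0.12 log units; within the scatter), nothing beyond the scatter. The estimate for compound 3 in this assay is 40 nM, within 15 nM to 120 nM.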

Compound 3, inhibition constant: 250 nM
Compound 3: middle estimate off by 6.3-fold (0.80 log units), on the low side; the measured number lies above the stated range.
By their numbers in this assay, from the lowest: compound 1; then compounds 2 and 3 (each within the scatter of the next).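

In this assay, pyridin-3-yl in place of phenyl on a saturated chain carbon bound to an aromatic nitrogen gives an 8.3-fold higher number from compound 1 to compound 3 (0.92 log units; beyond the scatter). This place, untouched by the halogen step, therefore responds to a single ring nitrogen, even though the heavy-atom count stays the same and only a hydrogen-bond acceptor enters. No evidence is at hand to explain this step. The compounds shown leave open whether the result depends on where the ring nitrogen sits, as pyridin-4-yl would show, and how a phenyl carrying a methoxy group or an amine would fare here.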